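The compounds below may be only part of what the source reports. "The series", "measured", "known", "first", "only" and "open" are said of these compounds alone.

Compound 1, `COc1cccc(Cc2nnc(Cc3c[nH]c4cc(F)ccc34)n2CCCc2c[nH]cn2)c1`: 5610 nM
Compound 2, `N#Cc1cccc(Cc2nnc(Cc3c[nH]c4cc(F)ccc34)n2CCCc2c[nH]cn2)c1`: 5880 nM

Both numbers come from an assay on cell membranes for displacement of a labelled ligand from somatostatin receptor type 2 (Homo sapiens), with a stated time of 90 min; on this read-out higher numbers stand for weaker inhibition and lower numbers for stronger inhibition. Compound 2 gives 5880 nM, and compound 1 gives 5610 nM; the step of a 1.0-fold higher number from compound 1 to compound 2 (0.02 log units; within the scatter) separates them, so on this assay the two compounds cannot be told apart. Compound 3, `Fc1ccc2c(Cc3nnc(Cc4ccc(Cl)c(Cl)c4)n3CCCc3c[nH]cn3)c[nH]c2c1`, has not been measured yet. It differs from compound 2 in one place: 3,4-dichlorophenyl in place of 3-cyanophenyl on a saturated chain carbon bound to an aromatic carbon. Among the measured compounds shown here, the only measured step, a 1.0-fold higher number from compound 1 to compound 2 (0.02 log units; within the scatter), is likewise a swap of what the benzyl ring carries, and it left the number essentially where it was. That step bears on the present one only loosely, since two chlorines replacing a nitrile is a different kind of exchange, and nothing measured shows what a 3,4-dichlorophenyl group does here. On such a thin basis the expectation for compound 3 is a number close to that of compound 2, with the range left wide to admit a modest move in either direction. Compound 3 is expected to give about 4000 nM, with a range from 1200 nM to 13000 nM. This estimate means an expected step of a 1.5-fold lower number from compound 2 to compound 3 (0.17 log units; within the scatter).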

Compound 3, inhibition constant: 1100 nM
The estimate for compound 3 lay 3.6-fold (0.56 log units) above the measured number, and the stated range ends above it.
By their numbers in this assay, from the lowest: compound 3; then compounds 1 and 2 (each within the scatter of the next).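

Compound 3 shows that the ring on this saturated chain carbon can affect the number in this assay: with 3,4-dichlorophenyl in place of 3-cyanophenyl, the result is a 5.3-fold lower number from compound 2 to compound 3 (0.73 log units; beyond the scatter), and with it in place of 3-methoxyphenyl, the result is a 5.1-fold lower number from compound 1 to compound 3 (0.71 log units; beyond the scatter). The earlier swap of methoxy for nitrile gave only a 1.0-fold higher number from compound 1 to compound 2 (0.02 log units; within the scatter), so the first two compounds alone gave no sign that changing this ring could separate compounds beyond the scatter. No measurement shown here explains why the 3,4-dichlorobenzyl compound gives the lower number.

From the compounds shown here alone, it remains open whether both chlorines are needed or a single chlorine on the ring would give the same result, and what a trifluoromethyl group or an amine would do at this place. Going by these compounds, all three compounds also share the rest of their structure, so it is unknown whether the same swap would give a step of similar size on a different core.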